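Changing the ring on the triazole nitrogen: compound 4

The source may report more compounds than this note shows. Statements on the series, on what has been measured and on what is new or still open speak of the compounds shown alone.

Three compounds share one core and differ only in the ring attached to an aromatic nitrogen. In a functional assay on NCI-H322 cells (Homo sapiens) for cytotoxicity, read by MTT assay, with a stated time of 24 h (on this read-out lower numbers stand for stronger inhibition and higher numbers for weaker inhibition), compound 1 `COc1ccc(/C=C\C(=O)O)c(OCc2cn(-c3cccc([N+](=O)[O-])c3)nn2)c1CC=C(C)C` gives 43200 nM, compound 2 `COc1ccc(/C=C\C(=O)O)c(OCc2cn(-c3ccccc3C#N)nn2)c1CC=C(C)C` gives 14400 nM, and compound 3 `COc1ccc(/C=C\C(=O)O)c(OCc2cn(-c3ccc(CO)cc3)nn2)c1CC=C(C)C` gives 27100 nM. Compound 3 sits between the other two, as a 1.6-fold lower number from compound 1 to compound 3 (0.20 log units; within the scatter) and a 1.9-fold higher number from compound 2 to compound 3 (0.27 log units; within the scatter) show, both gaps within the scatter. Compound 4 `COc1ccc(/C=C\C(=O)O)c(OCc2cn(-c3cccnc3Cl)nn2)c1CC=C(C)C` differs from compound 3 by 2-chloropyridin-3-yl in place of 4-(hydroxymethyl)phenyl on an aromatic nitrogen. Going by the values given here, the three measured swaps at this position bear on it: a 3.0-fold lower number from compound 1 to compound 2 (0.48 log units; beyond the scatter) was the only step beyond the scatter, and it was modest. A small step, likely within the scatter, is therefore expected. For compound 4 this means an expected step of a 1.1-fold lower number from compound 3 to compound 4 (0.04 log units; within the scatter). Compound 4 is estimated at 25000 nM, with a range from 10000 nM to 60000 nM.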

Compound 4, half-maximal inhibitory concentration: 42200 nM
The estimate for compound 4 lay 1.7-fold (0.23 log units) below the measured number, within the range that was stated.
By their numbers in this assay, from the lowest: compounds 2, 3, 4 and 1 (each within the scatter of the next, the first and the last beyond it).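

In this assay the 2-chloropyridin-3-yl ring of compound 4 cannot be told apart from 4-(hydroxymethyl)phenyl (a 1.6-fold higher number from compound 3 to compound 4 (0.19 log units; within the scatter)) or from 3-nitrophenyl (a 1.0-fold lower number from compound 1 to compound 4 (0.01 log units; within the scatter)). Against 2-cyanophenyl the gap is modest but beyond the scatter (a 2.9-fold higher number from compound 2 to compound 4 (0.47 log units; beyond the scatter)), so at this position the ring of compound 2 is the only one that separates from more than one other ring. No evidence at hand gives a reason for these steps. Still open, from the compounds shown here alone, is how this position would respond to a phenyl ring carrying an amine or a carboxylic acid, or to a longer chain in place of the ring.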